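A few compounds are considered here, and "the series" means these few. Any claim that something is new, unique, unknown or untested is made for them only; others in the source may bear on it.

Measured so far:
compound 1 `O=C(N/N=C/c1ccc(F)cc1)c1cccnc1Nc1cccc(C(F)(F)F)c1`: 43.2%
compound 2 `O=C(N/N=C/c1cccc(O)c1)c1cccnc1Nc1cccc(C(F)(F)F)c1`: 63.8%

In a functional assay on the whole organism (strain Wistar) for inhibition, with Rattus norvegicus as the target, read by paw edema, with a stated time of 1 h, at a dose of 10 mg/kg by the intraperitoneal route (on this read-out lower numbers stand for less inhibition and higher numbers for more inhibition at the one dose given (going by the name of the read-out)), compound 2 gives 63.8%, the higher of the two numbers, while compound 1 gives 43.2%. Among the compounds with values here, the only measured step is a number 20.6 percentage points higher from compound 1 to compound 2 (beyond the scatter), a swap of one aryl group for another. Compound 3 `O=C(N/N=C/c1ccc(O)c(O)c1)c1cccnc1Nc1cccc(C(F)(F)F)c1` differs from compound 2 by hydroxy in place of hydrogen on an aromatic carbon, turning 3-hydroxyphenyl into 3,4-dihydroxyphenyl. Within the data shown here, no measured step tests adding a hydroxy group to a ring that already carries one, so the one step bears on it only loosely. A small rise, or no change beyond the scatter, is expected. Compound 3 is estimated at 68%, range 52% to 82%, an expected step of a number 4.2 percentage points higher from compound 2 to compound 3 (within the scatter).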

Compound 3, a percentage reported as inhibition, in the whole organism at one dose (the size of the read-out at that dose, not a potency): 50.8%
For compound 3 the middle estimate is 17.2 percentage points above the measured one; the whole stated range lies above it.
By their numbers in this assay, from the lowest: compounds 1 and 3 (each within the scatter of the next); then compound 2.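

In this assay, a second hydroxy on the ring does not add to the effect of the first: the change gives a number 13 percentage points lower from compound 2 to compound 3 (beyond the scatter), so more hydroxy groups do not simply mean more inhibition here. With a number 7.6 percentage points higher from compound 1 to compound 3 (within the scatter), the 3,4-dihydroxyphenyl and 4-fluorophenyl rings cannot be told apart at this dose. Nothing available accounts for this result. Still open, going by these compounds, is how a methoxy group or an amine at this place on the ring would compare with hydroxy. A single dose also leaves open whether these differences would hold at other doses.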